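The compounds below may be only part of what the source reports. "The series", "measured", "known", "first", "only" and "open" are said of these compounds alone.

Measured in a functional assay on the whole organism with Rattus norvegicus as the target; a lower number here means that less compound is needed, a higher number that more compound is needed for the effect:
- compound 1 `CCOCCOC(=O)C(=O)Nc1nc(-c2cc(Br)no2)cs1`: 11 mg/kg
- compound 2 `CCOCCOC(=O)C(=O)Nc1nc(-c2cc(OC)no2)cs1`: 3 mg/kg

Of these two, compound 2 has the lower number, at 3 mg/kg. Going by the values given here, the only measured step is a 3.7-fold lower number from compound 1 to compound 2 (0.56 log units; beyond the scatter), a modest one beyond the scatter, with methoxy in place of bromo on an aromatic carbon.

Compound 3 `CCOCCOC(=O)C(=O)Nc1nc(-c2cc(OCc3ccccc3)no2)cs1` differs from compound 2 by phenyl in place of hydrogen on a saturated chain carbon bound to an oxygen on an aromatic ring, so methoxy becomes benzyloxy. Among the compounds with values here, no measured compound carries this phenyl, and the one measured step bears on the change only loosely. Going by a 3.7-fold lower number from compound 1 to compound 2 (0.56 log units; beyond the scatter), a step of similar modest size is expected, leaning towards a higher number, with the direction not fixed by the data. The expected step is a 1.7-fold higher number from compound 2 to compound 3 (0.22 log units; within the scatter). The estimate for compound 3 is 5 mg/kg, with an expected range from 1.5 mg/kg to 15 mg/kg.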

Compound 3, dose for half-maximal effect: 3.7 mg/kg
Beside the measured number, compound 3's estimate is 1.4-fold (0.13 log units) above it, within the range that was stated.
By their numbers in this assay, from the lowest: compounds 2 and 3 (each within the scatter of the next); then compound 1.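

In this assay, phenyl on the saturated chain carbon bound to an oxygen on an aromatic ring gives a 1.2-fold higher number from compound 2 to compound 3 (0.09 log units; within the scatter), so this assay does not separate methoxy from benzyloxy, and the six extra heavy atoms of the phenyl carry no measurable penalty here. Benzyloxy in place of bromo gives a 3.0-fold lower number from compound 1 to compound 3 (0.47 log units; beyond the scatter), so the advantage over bromo first seen with methoxy holds for a much larger oxygen-linked group as well. No measured evidence bears on the cause of either step.

On these data alone, whether the oxygen link itself matters remains open: an amine or a plain ethyl group in place of methoxy would separate the link from the group beyond it. As far as these compounds go, how much further the group can grow also remains open, for example with phenethyl or a longer chain on the same oxygen.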